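The source may hold more compounds than are shown below. What is called first, only, known or untested is meant among the compounds shown, and "the series" means these compounds.

In a functional assay on CCRF-CEM cells (Homo sapiens) for cytotoxicity, read by MTT assay, with a stated time of 72 h (a higher number here means that more compound is tolerated, a lower number that less compound is tolerated), compound 3 `CSc1nc(NCCCCCO)c2cccnc2n1` gives > 100000 nM, which is a limit of the assay rather than a number. Compound 1 `[SeH]c1nc(NCc2ccccc2)c2cccnc2n1` gives > 100000 nM, also a limit. Compound 2 `COc1ccc(CNc2nc(SC)nc3ncccc23)cc1` gives > 100000 nM, again a limit. Compound 3 therefore stands at the limit of > 100000 nM in this assay, at which 3 of the 3 values shown sit, and no measured number exists among the three. Compound 4 `CSc1nc(NCc2ccccc2)c2cccnc2n1` differs from compound 3 by phenyl in place of 4-hydroxybutyl on a saturated chain carbon bound to a nitrogen on an aromatic ring. For the measured compounds named here, no step between measured compounds is available, and compounds 1 and 2, which both carry the phenyl of compound 4 on that chain carbon, sit at the same limit, so no change beyond the scatter is expected in this assay. Compound 4 is expected to give 150000 nM, within a range from 60000 nM to 400000 nM. The estimated step that the limit leaves unreadable from compound 3 to compound 4 is expected to be none beyond the scatter.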

Compound 4, concentration lethal to 50% of the cells: > 100000 nM
Compound 4: only a limit was reported (the forecaster's own chance of this, stated with the estimate: 85%); the middle value is on the limit's open side.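

For the compounds shown here, compound 4, like compounds 1, 2 and 3, gives only a limit, so no step from any of these three to compound 4 can be read: the limit of > 100000 nM in this assay, at which 4 of the 4 values shown sit. The compounds shown leave open whether any of them differs from another in cytotoxicity, including whether phenyl and 4-hydroxybutyl differ.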